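Acid series: side-chain exchange from compound 2 to compound 4

This account rests on a few compounds, and the source may have more. Where it says the series, first, only, none or still open, it means among the compounds named here.

Measured compounds in a functional assay on the whole organism (Tail, strain ICR) with Mus musculus as the target, in the tail flick test, with a stated time of 90 min, at a dose of 25 umol/kg by the oral route; a higher number here means a stronger effect of the compound at the dose given, a lower number a weaker effect:
compound 1 `O=C(CN(c1nc(Cl)nc2[nH]cnc12)C1CC1)N[C@@H](CO)C(=O)OCc1ccccc1`: 34.5%
compound 2 `O=C(CN(c1nc(Cl)nc2[nH]cnc12)C1CC1)N[C@@H](CO)C(=O)O`: 43.9%
compound 3 `CCOC(=O)CN(c1nc(Cl)nc2c1ncn2C1CCCCO1)C1CC1`: 13%

Compound 2 stands highest of the three numbers in this assay. Nearest is compound 1, whose value lies within the scatter of compound 2; furthest is compound 3, whose value lies beyond the scatter below compound 2.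

Compound 4 `NC(=O)CC[C@H](NC(=O)CN(c1nc(Cl)nc2[nH]cnc12)C1CC1)C(=O)O` is not yet measured. Relative to compound 2 the change is carbamoylmethyl in place of hydroxy on a saturated chain carbon, two bonds along the chain from an amide-type nitrogen and a carbonyl carbon.

Going by the values given here, only one measured step exists, a number 9.4 percentage points higher from compound 1 to compound 2 (within the scatter), and it sits at another place than the change now considered. Among the compounds with values here, compounds 2 and 3 differ in more than one place, so their two values show only that compound 3 is lower. Within the data shown here, no measured step touches the hydroxymethyl side chain, so nothing argues for a step in either direction, and the expectation is no step beyond the scatter.

Compound 4 is therefore estimated at 40% in this assay, with a range from 22% to 58%. The expected step is a number 3.9 percentage points lower from compound 2 to compound 4 (within the scatter), a number within the scatter.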

Compound 4, a percentage reported as activity, at one dose (the size of the read-out at that dose, not a potency): 41.1%
For compound 4 the middle estimate is 1.1 percentage points below the measured one; low and high end bracket the measured number.
By their numbers in this assay, from the lowest: compound 3; then compounds 1, 4 and 2 (each within the scatter of the next).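

In this assay, going by these compounds alone, the exchange of hydroxymethyl for 2-carbamoylethyl at the side chain of the acid series gives a number 2.8 percentage points lower from compound 2 to compound 4 (within the scatter) and is the first measured step at this position. The entering carbamoylmethyl brings 4 heavy atoms where the hydroxy brought 1, with the same hydrogen-bond donor and acceptor counts, and the read-out at this dose does not separate the two side chains. The side chain therefore accepts this one exchange without a step beyond the scatter, but the data offer no measured basis for explaining the result.

From the compounds shown here alone, whether a carboxylic acid or a primary amine at the end of this side chain, or a chain longer than 2-carbamoylethyl, would stay within the scatter of compound 2 remains open. Also open, going by these compounds, is whether the same exchange would give a similar step with the benzyl ester of compound 1 in place of the free acid, and whether this assay would show the same picture at another dose or time.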